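Swapping a Pentyl Chain for an Amino Group on an Indole

The compounds below may be only part of what the source reports. "The series", "measured", "known", "first", "only" and "open" are said of these compounds alone.

Measured compounds:
- compound 1 `Cc1ccc(-c2cc3ccccc3[nH]2)cc1`: 9.33%
- compound 2 `CCCCCc1ccc(-c2cc3ccccc3[nH]2)cc1`: 0%

In an assay on isolated protein for inhibition of Aromatase (Homo sapiens), read by fluorescence, using NADPH, with a stated time of 30 min, tested at 50 uM (on this read-out higher numbers stand for more inhibition at the one concentration tested (going by the name of the read-out) and lower numbers for less inhibition), compound 1 gives 9.33%, and compound 2 gives 0%. For the measured compounds named here, the only measured step, a number 9.3 percentage points lower from compound 1 to compound 2 (within the scatter), adds four carbons to a one-carbon chain, and its size lies within the scatter, so on these two numbers compound 2 cannot be called weaker than compound 1; both sit near the bottom of the scale.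

Compound 3 `Nc1ccc(-c2cc3ccccc3[nH]2)cc1` is the next compound. It differs from compound 2 in one place: amino in place of pentyl on an aromatic carbon. This change removes the whole chain from that aromatic carbon and puts a small nitrogen group there instead. Going by the values given here, no measured step involves an amino group, so the only guide is that lengthening the chain between compound 1 and compound 2 left the read-out essentially unchanged. With nothing to point to a large move in either direction, the step of a number 6 percentage points higher from compound 2 to compound 3 (within the scatter) is expected to stay within the scatter.

Compound 3 is therefore estimated at 6%, with a range from 0% to 22%.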

Compound 3, a percentage reported as inhibition, at one concentration (the size of the read-out at that concentration, not a potency): 46.2%
Compound 3: the middle estimate sits 40.2 percentage points below what was measured; the measured number lies above the stated range.
By their numbers in this assay, from the lowest: compounds 2 and 1 (each within the scatter of the next); then compound 3.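

In this assay, this carbon of the six-membered aromatic ring now proves able to move the read-out: methyl and pentyl gave numbers within the scatter of each other, whereas amino gives a clear change, with a number 46.2 percentage points higher from compound 2 to compound 3 (beyond the scatter) and a number 36.9 percentage points higher from compound 1 to compound 3 (beyond the scatter) on the two comparisons. Both steps lie beyond the scatter, so the gain holds whichever of the two chains is replaced, and it shows that the kind of group here matters in a way that chain length alone did not reveal. The change swaps carbon for nitrogen and adds a hydrogen-bond donor and acceptor, but nothing available here shows which of these differences, if any, accounts for the higher number.

On these data alone, whether the gain is specific to the amino group remains open, and a hydroxyl, a methylamino, a dimethylamino or an acetamido group on the same carbon would help to test this. A single tested concentration also leaves open how potent compound 3 is, since it gives the size of the inhibition at that concentration and not a full dose-response measure.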